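This account rests on a few compounds, and the source may have more. Where it says the series, first, only, none or still open, it means among the compounds named here.

Measured in a functional assay on VA-13 cells (Homo sapiens) for cytotoxicity; a lower number here means that less compound is needed, a higher number that more compound is needed for the effect:

- Compound 1 `CCCCOc1cccc(-c2cc(O)c3c(C)c(C(=O)OCC)oc3c2)c1`: 0.85 ug/mL
- Compound 2 `CCCOc1ccc(-c2cc(O)c3c(C)c(C(=O)OCC)oc3c2)cc1`: > 4 ug/mL

Compound 2 is recorded as > 4 ug/mL, which is a limit of this assay and not a number. Its true position on the scale is therefore open. Compound 1 does give a number on the shared core, though it differs from compound 2 in more than one place, so the two values cannot be read as a single clean step.

Compound 3 `CCOC(=O)c1oc2cc(-c3ccc(OCCc4ccccc4)cc3)cc(O)c2c1C` turns the propoxy of compound 2 into phenethyloxy, with phenyl in place of methyl on a saturated chain carbon, two bonds along the chain from an oxygen on an aromatic ring. Within the data shown here, no measured pair in this set shows what a change of this kind does. A modest move towards a lower number is still expected, because compound 1 shows that this core can reach 0.85 ug/mL. The expected change is an at least 1.6-fold lower number from compound 2 to compound 3 (0.20 log units; that floor lies within the scatter), and this estimate is uncertain. A result reported only as a limit would also be no surprise. For compound 3 the estimated value is 2.5 ug/mL, with an expected range of 0.7 ug/mL to 9 ug/mL.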

Compound 3, half-maximal effective concentration: > 4 ug/mL
Compound 3 ended at the assay's limit; the forecaster's own chance of this, stated with the estimate: 35%; middle value at least 1.6-fold (0.20 log units) away from the limit.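

In this assay compound 3 gives > 4 ug/mL, a limit of the assay and not a number. Among these compounds, compound 2 also sits at a limit, so no step between compound 2 and compound 3 can be read. As far as these compounds go, what stays open is where either compound truly lies, and what phenyl in place of methyl does on this chain.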